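A few compounds are considered here, and "the series" means these few. Any claim that something is new, unique, unknown or untested is made for them only; others in the source may bear on it.

Measured so far:
- compound 1, `CC1=C(C(=O)O[C@H](C)CO[N+](=O)[O-])[C@H](c2cccc3nonc23)C([N+](=O)[O-])=C(C)C1`: 36500 nM
- compound 2, `CC1=C(C(=O)OCCO[N+](=O)[O-])[C@@H](c2cccc3nonc23)C([N+](=O)[O-])=C(C)C1`: 115 nM

Within the data shown here, in a functional assay (ileum) for antagonist activity, with Cavia porcellus as the target (on this read-out higher numbers stand for weaker inhibition and lower numbers for stronger inhibition), compound 2 gives 115 nM, the lowest of the two numbers known here. Among the measured compounds shown here, its only neighbour is compound 1, which in this assay gives 36500 nM, a far higher number lying well beyond the scatter; compound 1 differs from compound 2 in more than one place, so the two values can only be set side by side.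

Compound 3, `CC1=C(C(=O)OCCO[N+](=O)[O-])[C@H](c2cccc3nonc23)C([N+](=O)[O-])=C(C)C1`, is the next compound to be measured. Its relation to compound 2 is the two compounds have the same atoms and bonds and differ only in configuration as drawn: 1 of 1 stereo elements differ; a stereocentre at a saturated ring carbon is drawn R in compound 2 and S in compound 3. For the measured compounds named here, no single-change step between measured compounds exists to lean on, so the expectation rests on the nature of this change alone. The step of a 70-fold higher number from compound 2 to compound 3 (1.84 log units; beyond the scatter) is expected to be a clear weakening, well beyond the scatter, with compound 3 losing most of the inhibition seen for compound 2. Compound 3 is estimated to come in at about 8000 nM, with a range from 1200 nM to 50000 nM.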

Compound 3, half-maximal inhibitory concentration: 22400 nM
Estimate against measurement, compound 3: 2.8-fold (0.45 log units) below; the range from low to high includes it.
By their numbers in this assay, from the lowest: compound 2; then compounds 3 and 1 (each within the scatter of the next).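

In this assay the stereocentre at a saturated ring carbon, drawn R or S with nothing else altered, accounts for a 190-fold higher number from compound 2 to compound 3 (2.29 log units; beyond the scatter), a large step. The step can be laid to this position alone, and the ground for that is: the fact that compounds 2 and 3 differ only in the configuration as drawn The other step, a 1.6-fold lower number from compound 1 to compound 3 (0.21 log units; within the scatter), puts hydrogen in place of methyl on a saturated chain carbon and stays within the scatter, so this change does not visibly move the number in this pair, unlike the change at the ring carbon.

From the compounds shown here alone, whether the methyl change would stay as small with the ring stereocentre drawn R remains open. Also open, going by these compounds, is whether a longer chain or an amine in place of the present ester side chain would keep the low number seen with the R drawing.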